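Pyrrolidin-1-yl for Cyclopentyl on the Sulfonyl Sulfur

The source may hold more compounds than are shown below. What is called first, only, known or untested is meant among the compounds shown, and "the series" means these compounds.

In an ADME assay on the whole organism for pharmacokinetics, with Rattus norvegicus as the target (on this read-out lower numbers stand for lower oral bioavailability and higher numbers for higher oral bioavailability), compound 3 `O=S(=O)(c1cc(F)c(O)c2ncccc12)C1CCCC1` gives 32%. That lies within the scatter of compound 1 `O=S(=O)(c1ccc(O)c2ncccc12)C1CCCC1` at 24% and far short of compound 2 `O=S(=O)(c1ccc(F)cc1)c1cc(F)c(O)c2ncccc12` at 100%. Compound 4 `O=S(=O)(c1cc(F)c(O)c2ncccc12)N1CCCC1` is the next case: pyrrolidin-1-yl in place of cyclopentyl on a sulfonyl sulfur. Among the compounds with values here, two measured steps bear on it. The fluoro change gave only a number 8 percentage points higher from compound 1 to compound 3 (within the scatter), whereas a different exchange on the sulfonyl sulfur gave a number 68 percentage points lower from compound 2 to compound 3 (beyond the scatter), a large step showing that this place can matter. Within the data shown here, no measurement yet tests pyrrolidin-1-yl, so no step beyond the scatter is expected. The expected step is a number 6 percentage points higher from compound 3 to compound 4 (within the scatter). For compound 4 the estimate is 38%, with an expected range of 15% to 70%.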

Compound 4, oral bioavailability: 73%
The estimate for compound 4 lay 35 percentage points below the measured number; measured number outside the range, above it.
By their numbers in this assay, from the lowest: compounds 1 and 3 (each within the scatter of the next); then compound 4; then compound 2.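

With the count of heavy atoms unchanged, pyrrolidin-1-yl in place of cyclopentyl on the sulfonyl sulfur gives a number 41 percentage points higher from compound 3 to compound 4 (beyond the scatter) in this assay. This shows that a single ring nitrogen in place of carbon can separate two five-membered non-aromatic rings at this position, although 4-fluorophenyl remains apart, with pyrrolidin-1-yl in its place giving a number 27 percentage points lower from compound 2 to compound 4 (beyond the scatter). Nothing measured here explains either step. The compounds shown leave open how a morpholine, a piperidine or an open-chain dimethylamino group would compare on the sulfonyl sulfur. They also leave open whether the fluoro exchange would matter alongside pyrrolidin-1-yl.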